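The compounds below may be only part of what the source reports. "The series", "measured", "known", "first", "only" and "open" are said of these compounds alone.

Compound 1, `Cc1ccc(NC2=CC(=O)c3c(nc4n3[C@H]3OC[C@@H](O)[C@H]3OC4)C2=O)cc1`, compound 2, `Cc1ccc(NC2=CC(=O)c3c(nc4n3[C@H]3OC[C@@H](O)[C@H]3OC4)C2=O)cc1C`, and compound 3, `Cc1ccc(NC2=CC(=O)c3nc4n(c3C2=O)[C@H]2OC[C@@H](O)[C@H]2OC4)cc1`, were tested in a functional assay on MCF7 cells (Homo sapiens) for inhibition, read by sulforhodamine B assay; a higher number here means a weaker inhibitor, a lower number a stronger inhibitor. Compound 1 reaches only a limit there and gives > 4000 nM. Compound 2 gives 4950 nM in this assay, and compound 3 gives 1660 nM, the lower of the two numbers. The difference between the core of compound 3 and that of compound 2 is not broken down here. Compound 2 and compound 1 differ by hydrogen in place of methyl on an aromatic carbon, and the step that the limit leaves unreadable from compound 2 to compound 1 cannot be sized because of the limit of > 4000 nM in this assay, at which 1 of the 3 values shown sits.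

Compound 4, `O=C1C=C(Nc2ccccc2)C(=O)c2c1nc1n2[C@H]2OC[C@@H](O)[C@H]2OC1`, is not yet measured in this assay. It is related to compound 3 by hydrogen in place of methyl on an aromatic carbon, the same kind of change as that from compound 2 to compound 1, but not the same: there the hydrogen enters ortho to a methyl group and meta to a large group, here para to a large group. Since the earlier step is unreadable, the expectation for compound 4 rests on compound 3 at 1660 nM alone. Compound 4 is expected to show a step of a 1.5-fold higher number from compound 3 to compound 4 (0.18 log units; within the scatter), roughly within the scatter. Compound 4 is therefore estimated at 2500 nM in this assay, between 1000 nM and 6000 nM.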

Compound 4, half-maximal inhibitory concentration: > 4000 nM
Compound 4 gave a limit, no number; the forecaster's own chance of this, stated with the estimate: 25%; middle value at least 1.6-fold (0.20 log units) from the limit.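

Going from 4-methylphenyl to phenyl, with hydrogen in place of methyl on an aromatic carbon para to a large group, gives an at least 2.4-fold higher number from compound 3 to compound 4 (0.38 log units; beyond the scatter) in this assay, so on this core the loss of the methyl group weakens inhibition beyond the scatter. Compound 4 gives only a limit, > 4000 nM, which means that the size of this step is known only as a lower bound. The matching step from compound 2 to compound 1 on the other core cannot be read, and the one readable step therefore does not show whether the change carries from one core to the other, because the second step ends at a limit: the limit of > 4000 nM in this assay, at which 2 of the 4 values shown sit.

The compounds shown leave open how either core responds to other groups in place of that methyl group, such as a methoxy group, a chlorine atom or an ethyl group. They also leave open whether an amine or a carboxylic acid at the same place on the aromatic ring would hold the level of compound 3.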